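Para Substituent Swap on an Aromatic Amide

A few compounds are considered here, and "the series" means these few. Any claim that something is new, unique, unknown or untested is made for them only; others in the source may bear on it.

Measured so far:
- compound 1 `O=C(Nc1nc(-c2ccccc2)cs1)c1ccccc1`: 39 nM
- compound 2 `O=C(Nc1nc(-c2ccccc2)cs1)c1ccc(Cl)cc1`: 18 nM

For the measured compounds named here, in an assay for displacement of a labelled ligand from adenosine receptor A1 (Rattus norvegicus) (on this read-out lower numbers stand for stronger inhibition and higher numbers for weaker inhibition), compound 2 gives the lowest of the two numbers, and the only neighbour is compound 1 with the step of a 2.2-fold lower number from compound 1 to compound 2 (0.34 log units; beyond the scatter). Compound 3 `CC(C)(C)c1ccc(C(=O)Nc2nc(-c3ccccc3)cs2)cc1` differs from compound 2 by one change: tert-butyl in place of chloro on an aromatic carbon. Going by the values given here, only one measured step touches this position, a 2.2-fold lower number from compound 1 to compound 2 (0.34 log units; beyond the scatter), and it compares chloro with hydrogen, not tert-butyl with chloro. That step shows the position tolerates a group, but nothing measured tells how a tert-butyl compares. The expectation is therefore a step near zero, a 1.7-fold higher number from compound 2 to compound 3 (0.22 log units; within the scatter), with a wide uncertainty. Compound 3 is estimated at 30 nM, within a range of 8 nM to 120 nM.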

Compound 3, inhibition constant: 1360 nM
Compound 3: the middle estimate sits 45-fold (1.66 log units) below what was measured, and the stated range ends below it.
By their numbers in this assay, from the lowest: compound 2; then compound 1; then compound 3.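

In this assay this position, on an aromatic carbon para to a large group, does not accept every group: putting tert-butyl in place of chloro gives a 76-fold higher number from compound 2 to compound 3 (1.88 log units; beyond the scatter) and putting it in place of hydrogen gives a 35-fold higher number from compound 1 to compound 3 (1.54 log units; beyond the scatter). So the gain seen with chloro does not carry over to tert-butyl, whose 4 heavy atoms leave compound 3 weaker than both compound 1, which has only hydrogen here, and compound 2. Nothing shown gives a reason for this loss.

Still open, as far as these compounds go, is how the number moves with other groups at this place, such as methyl, fluoro or methoxy, which would show how much of the loss appears with a group other than tert-butyl. An amine or a carboxylic acid here is equally untested by the compounds shown.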